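A few compounds are considered here, and "the series" means these few. Any claim that something is new, unique, unknown or untested is made for them only; others in the source may bear on it.

Measured compounds:
compound 1 `Cc1ccc(-c2cn(C/C=C3\OC(=O)C(OCc4ccccc4)=C3OCc3ccccc3)nn2)cc1` — 7480 nM
compound 2 `O=C1O[C@H]([C@@H](O)Cn2cc(-c3cccc(O)c3)nn2)C(OCc2ccccc2)=C1OCc1ccccc1` — 39300 nM
compound 3 `CCCCCc1ccc(-c2cn(C[C@H](O)[C@H]3OC(=O)C(OCc4ccccc4)=C3OCc3ccccc3)nn2)cc1` — 8390 nM

In a functional assay on HeLa cells (Homo sapiens) for antiproliferative activity, read by MTT assay, with a stated time of 72 h (on this read-out lower numbers stand for stronger inhibition and higher numbers for weaker inhibition), compound 1 gives the lowest of the three numbers shown, though compound 3 sits within the usual scatter of it, while compound 2 lies beyond it. Compound 4 `O=C1O/C(=C\Cn2cc(-c3cccc(O)c3)nn2)C(OCc2ccccc2)=C1OCc1ccccc1` differs from compound 1 by 3-hydroxyphenyl in place of 4-methylphenyl on an aromatic carbon. Among the measured compounds shown here, one measured step bears on this change: a 4.7-fold lower number from compound 2 to compound 3 (0.67 log units; beyond the scatter), where a hydroxyl-bearing phenyl was exchanged for an alkyl-bearing phenyl on an aromatic carbon, although on a different shared core. The present step runs the other way, from a methyl-bearing phenyl to a hydroxyl-bearing one, so a higher number of similar size is expected: a 3.5-fold higher number from compound 1 to compound 4 (0.54 log units; beyond the scatter). Compound 4 is therefore estimated at 26000 nM, with a range from 12000 nM to 60000 nM.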

Compound 4, half-maximal inhibitory concentration: 74800 nM
Estimate against measurement, compound 4: 2.9-fold (0.46 log units) below; the whole stated range lies below it.
By their numbers in this assay, from the lowest: compounds 1 and 3 (each within the scatter of the next); then compounds 2 and 4 (each within the scatter of the next).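

In this assay, exchanging the group on this aromatic carbon of the five-membered ring also changes the result on the core of compound 1: 3-hydroxyphenyl in place of 4-methylphenyl gives a 10-fold higher number from compound 1 to compound 4 (1.00 log units; beyond the scatter). The sensitivity to this group is therefore not confined to the core of compound 2 and compound 3. Nothing measured here explains the size of this step. Still open, as far as these compounds go, is whether 4-hydroxyphenyl or 3-methylphenyl at this position would separate the contribution of the hydroxyl from that of its location on the phenyl ring.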